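The compounds below may be only part of what the source reports. "The series", "measured", "known", "first", "only" and "open" are said of these compounds alone.

Measured compounds: compound 1 `CC/N=C(\S)NCCCCCn1nc(-c2ccccc2)ccc1=O` with 51.8 mg/kg in a functional assay on the whole organism (stomach) with Rattus norvegicus as the target; a higher number here means that more compound is needed for the effect, a lower number that less compound is needed; compound 2 `CC/N=C(/NC#N)NCCCCn1nc(-c2ccccc2)ccc1=O` with 92 mg/kg; compound 3 `CC/N=C(\S)NCCCn1nc(-c2ccccc2)ccc1=O` with > 100 mg/kg.

The value for compound 3 in this assay is a limit, not a number. Compound 3 thus stands at the limit of the assay, (the limit of > 100 mg/kg in this assay, at which 1 of the 3 values shown sits). Compound 4 `N#CNC(=N)NCCCCn1nc(-c2ccccc2)ccc1=O` carries a change at the same position: a group of 7 heavy atoms (3 carbon, 4 nitrogen; no ring) in place of a group of 6 heavy atoms (3 carbon, 2 nitrogen, 1 sulfur; no ring), on a saturated chain carbon, three bonds along the chain from an aromatic nitrogen. Within the data shown here, one measured step bears on this change. Between compound 1 and compound 2 the same kind of exchange, a cyanoguanidine-type group entering for a thiourea-type group, gave a 1.8-fold higher number from compound 1 to compound 2 (0.25 log units; within the scatter). The comparison of compound 1 with compound 3 shows an at least 1.9-fold higher number from compound 1 to compound 3 (0.28 log units; that floor lies within the scatter), so the shorter chain in compound 3 already sits at the limit. Among the measured compounds shown here, the one relevant step gives no reason to expect a move beyond the scatter in this assay, and the starting point is itself a limit. Compound 4 is therefore expected to remain near or beyond the limit, estimated at 150 mg/kg, within 70 mg/kg to 400 mg/kg. This expectation amounts to a step that the limit leaves unreadable from compound 3 to compound 4.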

Compound 4, dose for half-maximal effect: 77.2 mg/kg
Beside the measured number, compound 4's estimate is 1.9-fold (0.29 log units) above it; low and high end bracket the measured number.
By their numbers in this assay, from the lowest: compounds 1, 4 and 2 (each within the scatter of the next). At a limit, above all of these: compound 3.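

In this assay compound 4 gives 77.2 mg/kg, and the exchange of the thiourea-type group for the cyanoguanidine-type group, on a saturated chain carbon, three bonds along the chain from an aromatic nitrogen, reads as an at least 1.2-fold lower number from compound 3 to compound 4 (0.11 log units; that floor lies within the scatter). The value of compound 3 remains a limit, not a number: the limit of > 100 mg/kg in this assay, at which 1 of the 4 values shown sits. The other two steps, a 1.2-fold lower number from compound 2 to compound 4 (0.08 log units; within the scatter) and a 1.5-fold higher number from compound 1 to compound 4 (0.17 log units; within the scatter), show compound 4 measurable in the same range as compound 1 and compound 2, with no separation among the three.

The full size of the exchange at this place stays unread while compound 3 stands at a limit. As far as these compounds go, how a urea or a longer chain carrying the cyanoguanidine-type group would fare in this assay remains open.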